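This account rests on a few compounds, and the source may have more. Where it says the series, first, only, none or still open, it means among the compounds named here.

Measured compounds:
- Compound 1, `C#CCNC1CCc2c(OCCc3cc(NC(=O)c4ccccc4)ccc3Cl)cccc21`: "not determined" (no result reported) in an ADME assay on cells for inhibition of Amine oxidase [flavin-containing] A (Homo sapiens), read by fluorescence and Amplex Red, with stated times of 30 min and 15 min; on this read-out lower numbers stand for stronger inhibition and higher numbers for weaker inhibition
- Compound 2, `C#CCNC1CCc2c(OCCc3cc(NC(=O)CO)ccc3Cl)cccc21`: 252000 nM

The series shares one core, to which a two-carbon linker carries a chlorinated phenyl ring bearing an amide. Compound 1 differs from the others in that amide, which is a benzamide; for compound 1 no number was obtained in this assay, so nothing can be said of it. Compound 2 carries a (hydroxymethyl)carbonyl amide in its place and is the only compound with a number; in this assay compound 2 gives 252000 nM, a weak inhibition by any measure, and on the numbers shown it stands alone, with no second value to set beside it.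

Compound 3, `C#CCNC1CCc2c(OCCc3cc(NC(=O)COC(C)=O)ccc3Cl)cccc21`, is not yet measured. It differs from compound 2 by acetyl in place of hydrogen on an oxygen on a saturated carbon. Going by the values given here, no step between two measured compounds is available to size this change, so the expectation rests on the single value of compound 2 alone. A step of no more than the usual scatter is expected in this assay, in either direction; the estimated step of a 1.1-fold lower number from compound 2 to compound 3 (0.06 log units; within the scatter) is accordingly small. Compound 3 is expected to give about 220000 nM in this assay, within a range from 60000 nM to 700000 nM.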

Compound 3, half-maximal inhibitory concentration: 437000 nM
Estimate against measurement, compound 3: 2.0-fold (0.30 log units) below; the measured number falls inside the stated range.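

In this assay, going by these compounds alone, acetyl in place of hydrogen on the oxygen of the (hydroxymethyl)carbonyl amide gives the first measured step at this position, a 1.7-fold higher number from compound 2 to compound 3 (0.24 log units; within the scatter), so the hydroxy and acetoxy forms are not separated on this read-out. The swap brings in 3 heavy atoms, with no ring and no net charge, yet both compounds stay in the same weak range, which shows that on this pair, capping the hydroxy as its acetate does not move the number beyond the scatter. No measurement shown bears on why the two values lie so close.

This single step does not show whether any other group at this place would give a number clearly apart from compound 2, and the benzamide of compound 1 offers no value for comparison. Still open, on these data alone, is how an amine or a carboxylic acid in place of the hydroxy, or a longer chain between the amide carbonyl and the oxygen, would read in this assay.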